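The source may report more compounds than this note shows. Statements on the series, on what has been measured and on what is new or still open speak of the compounds shown alone.

Compound 3 `O=c1[nH]c(=O)n(CCC(CO)CO)cc1C#CC1CC1` carries a cyclopropylethynyl group on the shared core. In a functional assay on MCF7 cells (Homo sapiens) for antiproliferative activity, read by MTT assay, with a stated time of 72 h (a higher number here means a weaker inhibitor, a lower number a stronger inhibitor), compound 3 gives > 100000 nM, which is a limit of the assay rather than a number, so compound 3 stands at the limit of > 100000 nM in this assay, at which 1 of the 3 values shown sits, and is bounded from one side only. Compound 1 `O=c1[nH]c(=O)n(CCC(CO)CO)cc1-c1ccco1` carries furan-2-yl in its place. In this assay compound 1 gives < 10 nM, likewise a limit of the assay, at the limit of < 10 nM in this assay, at which 1 of the 3 values shown sits. Compound 2 `O=c1[nH]c(=O)n(CCC(CO)CO)cc1C#Cc1cc(F)cc(F)c1` has 3,5-difluorophenyl on the triple-bonded carbon, and in this assay compound 2 gives 63100 nM. The step of an at least 10000-fold higher number from compound 1 to compound 3 (4.00 log units; beyond the scatter) is large, whereas an at least 1.5-fold higher number from compound 2 to compound 3 (0.19 log units; that floor lies within the scatter) cannot be placed beyond the scatter.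

Compound 4 `CCCCCCCCC#Cc1cn(CCC(CO)CO)c(=O)[nH]c1=O` differs from compound 3 by octyl in place of cyclopropyl on a triple-bonded carbon. Going by the values given here, the only measured step at the same place, an at least 1.5-fold higher number from compound 2 to compound 3 (0.19 log units; that floor lies within the scatter), bears on it, and that step ended at a limit. Among the compounds with values here, no measured step points back toward lower numbers for a chain on that carbon. Compound 4 is therefore expected to stay near the limit, with an estimated 100000 nM in this assay, within 30000 nM to 300000 nM. The expected step is a number no higher from compound 3 to compound 4 (the limit leaves the size open).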

Compound 4, half-maximal inhibitory concentration: 40300 nM
Compound 4: middle estimate off by 2.5-fold (0.39 log units), on the high side; measured number inside the range.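

In this assay, going by these compounds alone, the octyl chain gives the only measured change on the triple-bonded carbon that lies beyond the scatter, an at least 2.4-fold lower number from compound 3 to compound 4 (0.39 log units; beyond the scatter), so this carbon does respond to what it carries. Set against the 3,5-difluorophenyl group, the same chain makes no readable difference, a 1.6-fold lower number from compound 2 to compound 4 (0.19 log units; within the scatter), which means these two groups cannot be told apart in this assay. The reading for compound 3 is a limit of the assay, so the size of its step stays open: the limit of > 100000 nM in this assay, at which 1 of the 4 values shown sits.

The compounds shown leave open whether a shorter chain such as butyl, or an amine or a hydroxyl at the end of the octyl chain, would change the number on that carbon. They also leave open whether any group on the triple bond can come near furan-2-yl in its effect on the shared core.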